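Swapping Fluoro for Bromo on a Benzyl Ether Core

A few compounds are considered here, and "the series" means these few. Any claim that something is new, unique, unknown or untested is made for them only; others in the source may bear on it.

Compound 3 `Fc1ccc(COc2nc3ccccc3s2)cc1` gives 51.9% in a functional assay on the whole organism with Mus musculus as the target, in the writhing test, at a dose of 100 mg/kg by the intraperitoneal route; a lower number here means less inhibition, a higher number more inhibition at the dose given (going by the name of the read-out). It stands level with compound 1 `c1ccc(COc2nc3ccccc3s2)cc1`, which gives 51.9% in this assay, and together these two form the lowest of the three numbers, since no change at the digits printed from compound 1 to compound 3 (within the scatter). Furthest from compound 3 is compound 2 `O=[N+]([O-])c1ccc(COc2nc3ccccc3s2)cc1`, which gives 97% in this assay, so that a number 45.1 percentage points lower from compound 2 to compound 3 (beyond the scatter).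

Compound 4 `Brc1ccc(COc2nc3ccccc3s2)cc1` differs from compound 3 in a single place: bromo in place of fluoro on an aromatic carbon.

Of the measured steps, the one most closely related is the halogen step no change at the digits printed from compound 1 to compound 3 (within the scatter), which left the number untouched. Among the compounds with values here, the nitro step a number 45.1 percentage points higher from compound 1 to compound 2 (beyond the scatter) shows that a group at this carbon can move the number a great deal, but no bromo compound has been measured, so that step offers no direct guide. On this basis compound 4 is expected to give about 55% in this assay, between 35% and 80%. The estimated step of a number 3.1 percentage points higher from compound 3 to compound 4 (within the scatter) is expected to stay within the scatter.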

Compound 4, a percentage reported as inhibition, in the whole organism at one dose (the size of the read-out at that dose, not a potency): 51.9%
Estimate against measurement, compound 4: 3.1 percentage points above, within the range that was stated.
By their numbers in this assay, from the lowest: compounds 1, 3 and 4 (each within the scatter of the next); then compound 2.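

In this assay, a second halogen now gives the same picture at this aromatic carbon: no change at the digits printed from compound 3 to compound 4 (within the scatter) and, against the unsubstituted ring, no change at the digits printed from compound 1 to compound 4 (within the scatter), so neither fluoro nor bromo separates from hydrogen here, despite the difference in size between the two halogens' atoms. Nitro remains the only group shown at this carbon that stands apart, with a number 45.1 percentage points lower from compound 2 to compound 4 (beyond the scatter), matching the gap already seen for the fluoro compound. No measurement is available that explains why the two halogens match hydrogen while nitro does not.

As far as these compounds go, it remains open whether the high number belongs to nitro alone or would also appear with a nitrile, an amine or a carboxylic acid at this carbon. The compounds shown also leave open whether bromo would behave the same way at another carbon of this ring.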